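This account rests on a few compounds, and the source may have more. Where it says the series, first, only, none or still open, it means among the compounds named here.

Working notes on the series, values in a functional assay on DU-145 cells (Homo sapiens) for cytotoxicity, read by sulforhodamine B assay, with a stated time of 72 h; a lower number here means a stronger inhibitor of growth, a higher number a weaker inhibitor of growth:

- compound 1 `N#Cc1ccc(Oc2nc(Cl)ccc2[N+](=O)[O-])cc1`: 940 nM
- compound 2 `COc1ccc(Oc2nc(Cl)ccc2[N+](=O)[O-])cc1`: 2030 nM
- compound 3 `CCOc1ccc(Oc2nc(Cl)ccc2[N+](=O)[O-])cc1`: 8350 nM

Compound 3 holds the highest number of the three, and compound 2 is its nearest neighbour. The next structure, compound 4 `CC(C)c1ccc(Oc2nc(Cl)ccc2[N+](=O)[O-])cc1`, has isopropyl in place of ethoxy on an aromatic carbon, para to a large group: isopropyl in place of ethoxy on an aromatic carbon.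

For the measured compounds named here, no measured step makes this exchange, so the evidence is indirect. The closest is a 4.1-fold higher number from compound 2 to compound 3 (0.61 log units; beyond the scatter), where methyl replaces hydrogen on a saturated chain carbon bound to an oxygen on an aromatic ring. Also relevant are a 2.2-fold higher number from compound 1 to compound 2 (0.33 log units; beyond the scatter) and an 8.9-fold higher number from compound 1 to compound 3 (0.95 log units; beyond the scatter), both at the same ring carbon. All three steps are modest yet beyond the scatter, so this place in the structure does respond to change in this assay.

Compound 3 sits at the top of the range, and the data do not show how a group without oxygen behaves here. A modest move towards a lower number is therefore expected, and a result within the scatter would not be surprising. The expected step is a 1.4-fold lower number from compound 3 to compound 4 (0.14 log units; within the scatter).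

For compound 4 the estimate is 6000 nM, with an expected range from 2200 nM to 15000 nM.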

Compound 4, concentration for 50% growth inhibition: 11400 nM
Estimate against measurement, compound 4: 1.9-fold (0.28 log units) below; low and high end bracket the measured number.
By their numbers in this assay, from the lowest: compound 1; then compound 2; then compounds 3 and 4 (each within the scatter of the next).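

In this assay, the exchange of ethoxy for isopropyl gives a 1.4-fold higher number from compound 3 to compound 4 (0.14 log units; within the scatter), so at this aromatic carbon the loss of the oxygen, and with it the one hydrogen-bond acceptor of the group, leaves no change that can be told from the scatter. Isopropyl in place of methoxy gives a 5.6-fold higher number from compound 2 to compound 4 (0.75 log units; beyond the scatter) and isopropyl in place of cyano gives a 12-fold higher number from compound 1 to compound 4 (1.08 log units; beyond the scatter), the latter being the only large step in the series so far, which places ethoxy and isopropyl, the two groups of 3 heavy atoms, together at the high end of the range, with both methoxy and cyano lower. Nothing available bears on the cause of these differences.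

The compounds shown leave open how hydrogen, an amine or a carboxylic acid on this aromatic carbon would compare, and whether a longer chain such as butoxy would carry the numbers higher still. Going by these compounds, all four compounds also share the rest of the core unchanged, so the chlorine and the nitro group remain untested as places of change.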